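The source may hold more compounds than are shown below. What is called first, only, known or untested is meant among the compounds shown, and "the series" means these compounds.

Measured so far:
- Compound 1, `N#Cc1ccc(Nc2nc(Oc3ccnc4ccccc34)nc(N3CCCCC3)n2)cc1C(F)(F)F`: 94900 nM
- Compound 2, `N#Cc1ccc(Nc2nc(Oc3ccnc4ccccc34)nc(N3CCN(c4ccccc4Cl)CC3)n2)cc1C(F)(F)F`: 92600 nM

Both numbers come from a functional assay on DU-145 cells (Homo sapiens) for cytotoxicity, read by sulforhodamine B assay, with a stated time of 48 h; a lower number here means a stronger inhibitor of growth, a higher number a weaker inhibitor of growth. Compound 2 has the lowest of the two numbers, but its nearest neighbour is compound 1, and the gap between them lies within the usual scatter, so the two cannot be told apart on these data. Both are weak inhibitors of growth in this assay.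

Compound 3, `CC(C)N1CCN(c2nc(Nc3ccc(C#N)c(C(F)(F)F)c3)nc(Oc3ccnc4ccccc34)n2)CC1`, has not yet been measured in this assay. It differs from compound 2 in one place: isopropyl in place of 2-chlorophenyl on an amine nitrogen in a ring. No change between two measured compounds is available as a guide, and the two measured values show that a large change at this part of the molecule left the number where it was. The expectation is therefore for a step no larger than the scatter, in no particular direction: a 1.0-fold higher number from compound 2 to compound 3 (0.01 log units; within the scatter). Compound 3 is expected to give about 95000 nM, with a likely range from 40000 nM to 200000 nM.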

Compound 3, concentration for 50% growth inhibition: > 100000 nM
Compound 3: only a limit was reported; the forecaster's own chance of this, stated with the estimate: 25%; middle value at least 1.0-fold (0.02 log units) away from the limit.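

In this assay compound 3 gives > 100000 nM, which is a limit of the assay and not a number. Isopropyl in place of 2-chlorophenyl gives an at least 1.0-fold higher number from compound 2 to compound 3 (0.03 log units; that floor lies within the scatter), and 4-isopropylpiperazin-1-yl in place of piperidin-1-yl gives an at least 1.0-fold higher number from compound 1 to compound 3 (0.02 log units; that floor lies within the scatter). So isopropyl, which has no ring, gives only weak inhibition of growth on this amine nitrogen, as 2-chlorophenyl does, but the true size of both steps cannot be read because only a floor is known: the limit of > 100000 nM in this assay, at which 1 of the 3 values shown sits.

Going by these compounds, whether a carboxylic acid or a longer chain ending in an amine on this nitrogen would give a clearly lower number remains open. So does whether any change to this position matters at all while the shared core stays the same.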